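A few compounds are considered here, and "the series" means these few. Any claim that something is new, unique, unknown or untested is made for them only; others in the source may bear on it.

The compounds here share one core and differ only in the amine set three bonds along the chain from an oxygen on an aromatic ring. Compound 1 `COc1cc2c(Nc3ccc(C#N)cc3)ncnc2cc1OCCCN(C)C` carries the smallest amine; in a functional assay on A549 cells (Homo sapiens) for antiproliferative activity, read by MTT assay, with a stated time of 72 h (on this read-out higher numbers stand for weaker inhibition and lower numbers for stronger inhibition), compound 1 gives 60500 nM. Compound 2 `COc1cc2c(Nc3ccc(C#N)cc3)ncnc2cc1OCCCN1CCC(CO)CC1` carries a ring amine instead. In this assay compound 2 gives only a limit, > 100000 nM, so no number is known for it; it sits at the limit of > 100000 nM in this assay, at which 1 of the 2 values shown sits. The step of an at least 1.6-fold higher number from compound 1 to compound 2 (0.21 log units; that floor lies within the scatter) is thus only a floor. Compound 3 `CCN1CCN(CCCOc2cc3ncnc(Nc4ccc(C#N)cc4)c3cc2OC)CC1` changes the ring amine once more: 4-ethylpiperazin-1-yl in place of 4-(hydroxymethyl)piperidin-1-yl on a saturated chain carbon, three bonds along the chain from an oxygen on an aromatic ring. For the measured compounds named here, the one measured step that bears on this, from a small amine to a ring amine, moved the number little if at all, so a step of similar small size and no clear direction is expected, an at least 1.1-fold lower number from compound 2 to compound 3 (0.04 log units; that floor lies within the scatter). Compound 3 is therefore expected to give about 90000 nM, between 35000 nM and 250000 nM, and may well again return only a limit.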

Compound 3, half-maximal inhibitory concentration: 16000 nM
The estimate for compound 3 lay 5.6-fold (0.75 log units) above the measured number; measured number outside the range, below it.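

The amine at this place clearly affects the read-out, and ring amines of the same size do not behave alike. In this assay the change to 4-ethylpiperazin-1-yl gives an at least 6.2-fold lower number from compound 2 to compound 3 (0.79 log units; beyond the scatter) even though both groups count the same number of heavy atoms, and this step is only a floor. Compound 2 gives only a limit and not a number: the limit of > 100000 nM in this assay, at which 1 of the 3 values shown sits. The same ring amine also separates from the smallest amine, with a 3.8-fold lower number from compound 1 to compound 3 (0.58 log units; beyond the scatter) and thus a change beyond the scatter, which the earlier step could not show.

Still open, as far as these compounds go, is whether the second ring nitrogen or the ethyl group accounts for the step, which morpholin-4-yl or unsubstituted piperazin-1-yl could help to separate. Also open, from the compounds shown here alone, is how a butyl chain in place of the propyl chain would read out.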